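The source may hold more compounds than are shown below. What is called first, only, known or untested is meant among the compounds shown, and "the series" means these compounds.

Series notes. Compound 1 `Fc1ccccc1NC(=S)N/N=C/c1ccc2ccccc2n1` carries a 2-fluorophenyl on the amide-type nitrogen. In a functional assay on HeLa cells (Homo sapiens) for antiproliferative activity, read by sulforhodamine B assay, with a stated time of 72 h (a lower number here means a stronger inhibitor, a higher number a weaker inhibitor), compound 1 gives only a limit, > 100000 nM, and that value is one of two reported here (the limit of > 100000 nM in this assay, at which 1 of the 2 values shown sits). Compound 2 `S=C(N/N=C/c1ccc2ccccc2n1)Nc1cccc(Br)c1` carries 3-bromophenyl in the same place. In this assay, among the compounds with values here, compound 2 gives 70000 nM, the only real number in the set. The step of an at least 1.4-fold lower number from compound 1 to compound 2 (0.15 log units; that floor lies within the scatter) is the sole measured one, and its floor lies within the scatter, so no direction can be read from it. Compound 3 `NC(=S)N/N=C/c1ccc2ccccc2n1` is the next one: hydrogen in place of 3-bromophenyl on an amide-type nitrogen. Within the data shown here, the only measured step exchanged one aromatic group for another on that nitrogen and left the number unchanged within scatter; no measured step removes the group altogether, so it gives no direct guide on the size of this change. With both reported compounds weak and one sitting at the limit, compound 3 is expected to remain weak in this assay, with the estimated step of a 1.4-fold higher number from compound 2 to compound 3 (0.15 log units; within the scatter) and an estimated value of 100000 nM, between 20000 nM and 500000 nM, with a fair chance that this assay returns only a limit.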

Compound 3, half-maximal inhibitory concentration: 960 nM
Compound 3: middle estimate off by 100-fold (2.02 log units), on the high side; measured number outside the range, below it.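

In this assay, the step between two aromatic groups on the amide-type nitrogen gave no readable direction, whereas removing the aromatic group altogether has a large effect: a 73-fold lower number from compound 2 to compound 3 (1.86 log units; beyond the scatter). The step from the other aromatic compound points the same way, an at least 100-fold lower number from compound 1 to compound 3 (2.01 log units; beyond the scatter), so compound 3, with only hydrogen on that nitrogen, stands as the strongest of the three, and this position proves far more sensitive to the change from an aromatic group to hydrogen than the earlier pair could show. The value for compound 1 is a limit, so its step gives only a floor and not a full size: the limit of > 100000 nM in this assay, at which 1 of the 3 values shown sits.

The compounds shown leave open whether any group on this nitrogen costs activity or whether the loss is tied to the substituted phenyl rings, since a methyl, a short alkyl chain or an unsubstituted phenyl there would separate those readings. They also give no reason for the large gain with hydrogen, and they leave open whether a second group on that nitrogen, or an oxygen in place of the thiocarbonyl sulfur, would keep it.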